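The source may hold more compounds than are shown below. What is called first, only, known or untested is meant among the compounds shown, and "the series" means these compounds.

Three carbamates were tested in an assay on isolated protein for inhibition of Fatty-acid amide hydrolase 1 (Rattus norvegicus), read by fluorescence (a higher number here means a weaker inhibitor, a lower number a stronger inhibitor), and each gave only a limit of the assay rather than a number. Compound 1, `N#Cc1cccc(OC(=O)N2CCC(OC(c3ccccc3)c3ccccc3)CC2)c1`, gives > 1000 nM. Compound 2, `N#Cc1ccc(F)c(OC(=O)N2CCC(C(c3ccccc3)c3ccccc3)CC2)c1`, gives > 1000 nM. Compound 3, `N#Cc1cccc(OC(=O)N2CCC(C(c3ccc(Cl)cc3)c3ccc(Cl)cc3)CC2)c1`, gives > 1000 nM. Compound 2 therefore stands at the limit, as summed up in the limit of > 1000 nM in this assay, at which 3 of the 3 values shown sit, and nothing in these figures separates it from the other two. Compound 4, `N#Cc1cccc(OC(=O)N2CCC(C(c3ccccc3)c3ccccc3)CC2)n1`, has not yet been measured. It differs from compound 2 in one place: 6-cyanopyridin-2-yl in place of 5-cyano-2-fluorophenyl on an oxygen next to a carbonyl group. Within the data shown here, no step between measured compounds is available, so the expectation rests only on where compound 2 sits. The step is expected to be a step that the limit leaves unreadable from compound 2 to compound 4, with the most likely outcome that the limit is reached again and any shift toward stronger inhibition staying near the scatter. Compound 4 is expected to give 1500 nM in this assay, within 300 nM to 8000 nM.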

Compound 4, half-maximal inhibitory concentration: > 1000 nM
Compound 4 ended at the assay's limit; the forecaster's own chance of this, stated with the estimate: 65%; the middle value lies beyond the limit too.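

Among these compounds, compound 4 gives > 1000 nM in this assay, a limit of the assay, and compound 2 sits at the same limit, so no step between compound 2 and compound 4 can be read. The compounds shown leave open how strongly any of them inhibits, and whether 6-cyanopyridin-2-yl in place of 5-cyano-2-fluorophenyl changes inhibition at all.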